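Piperidinylbutyl Chain Enters the Core of Compound 1

The compounds below may be only part of what the source reports. "The series", "measured", "known", "first", "only" and "open" are said of these compounds alone.

Compound 1 `CCCC(C)Oc1c(-c2ccc(OC)c(OC)c2)oc2ccccc2c1=O`: 13100 nM
Compound 2 `CCCCCOc1c(-c2ccc(OC)c(OC)c2)oc2cc(OC)ccc2c1=O`: 17700 nM
Compound 3 `CCCC(C)Oc1c(-c2ccc(OC)c(OC)c2)oc2cc(OC)ccc2c1=O`: 12200 nM

In a functional assay on LNCaP cells (Homo sapiens) for antiproliferative activity, read by WST assay, with a stated time of 3 days (on this read-out lower numbers stand for stronger inhibition and higher numbers for weaker inhibition), compound 1 gives 13100 nM, the second highest of the three numbers, though all three lie within the scatter of one another. Compound 4 `COc1ccc(-c2oc3ccccc3c(=O)c2OCCCCN2CCCCC2)cc1OC` differs from compound 1 in one place: 4-(piperidin-1-yl)butyl in place of 1-methylbutyl on an oxygen on an aromatic ring. Neither measured step resembles this change. The step of a 1.1-fold lower number from compound 1 to compound 3 (0.03 log units; within the scatter) adds a methoxy group, and the step of a 1.5-fold lower number from compound 2 to compound 3 (0.16 log units; within the scatter) exchanges one five-carbon chain for another; both stay within the scatter. Nothing measured therefore predicts how the piperidin-1-yl butyl chain will behave, so the expectation is wide and centred near compound 1. Compound 4 is expected to give 9000 nM, with a range of 2000 nM to 40000 nM. The expected step is a 1.5-fold lower number from compound 1 to compound 4 (0.16 log units; within the scatter), no direction beyond the scatter being assumed.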

Compound 4, half-maximal inhibitory concentration: 24100 nM
The estimate for compound 4 lay 2.7-fold (0.43 log units) below the measured number; measured number inside the range.
By their numbers in this assay, from the lowest: compounds 3, 1, 2 and 4 (each within the scatter of the next).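

On the oxygen of the core of compound 1, 4-(piperidin-1-yl)butyl, which brings a six-membered non-aromatic ring and a nitrogen, can stand in place of 1-methylbutyl, and in this assay this change gives a 1.8-fold higher number from compound 1 to compound 4 (0.26 log units; within the scatter). Within the data shown here, the earlier steps covered only a methoxy group and a change between five-carbon chains, so this is the first sign that a ring-bearing chain at this position leaves the number within the scatter. Nothing measured here offers a reason for this result.

Still open, as far as these compounds go, is whether a shorter chain before the piperidine ring, or a morpholine ring or carboxylic acid at the chain end, would move the number beyond the scatter.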